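The source may report more compounds than this note shows. Statements on the series, on what has been measured and on what is new or still open speak of the compounds shown alone.

Measured compounds:
Compound 1, `c1coc(-c2ccccc2OCC2=NCCN2)c1`, in a functional assay for activation of Alpha-1B adrenergic receptor (Homo sapiens), read by calcium flux (on this read-out lower numbers stand for an effect already at smaller amounts and higher numbers for an effect only at larger amounts of compound), compound 1 gives 10 nM.
Compound 2, `c1ccc(-c2ccns2)c(OCC2=NCCN2)c1`, in this assay compound 2 gives 12.6 nM.

Compound 1 stands at the lowest of the two numbers in this assay, with compound 2 nearest to it; the two values differ only within the scatter, so no order between them can be claimed. Within the data shown here, the single measured step, a 1.3-fold higher number from compound 1 to compound 2 (0.10 log units; within the scatter), exchanges the furan-2-yl of compound 1 for 1,2-thiazol-5-yl and leaves the read-out essentially unchanged.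

Compound 3, `Cc1cc(-c2ccccc2OCC2=NCCN2)sn1`, has not yet been measured. It differs from compound 1 as follows: 3-methyl-1,2-thiazol-5-yl in place of furan-2-yl on an aromatic carbon. The step from compound 1 to compound 2 bears on this change, since both replace furan-2-yl with a 1,2-thiazol-5-yl-type group on the same aromatic carbon; that step was within the scatter. Among the measured compounds shown here, the additional feature of compound 3, the 3-methyl-1,2-thiazol-5-yl group, has no measured counterpart, so nothing beyond the scatter is expected in this assay from it. Compound 3 is therefore estimated at 15 nM, with a range from 5 nM to 45 nM. The expected step is a 1.5-fold higher number from compound 1 to compound 3 (0.18 log units; within the scatter).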

Compound 3, half-maximal effective concentration: < 100000 nM
Compound 3: a limit, no number; the forecaster's own chance of this, stated with the estimate: 3%; the middle value lies beyond the limit too.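

In this assay compound 3 gives < 100000 nM, which is a limit of the assay and not a number. The steps to compound 3 from compound 1 and from compound 2 therefore cannot be read. The compounds shown leave open whether methyl in place of hydrogen on the 1,2-thiazol-5-yl group changes the read-out at all.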